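Removing the methyl from the ring nitrogen of compound 3

The source may report more compounds than this note shows. Statements on the series, on what has been measured and on what is new or still open speak of the compounds shown alone.

This account follows compound 3 `CCN(CC)CC(=O)Nc1ccc(-c2nc3cc(C(F)(F)F)ccc3n2C)cc1`, in which the five-membered ring of the core carries a methyl on its aromatic nitrogen. In an ADME assay on Vero cells (Chlorocebus sabaeus) for cytotoxicity (on this read-out higher numbers stand for lower toxicity in this test and lower numbers for higher toxicity in this test), compound 3 gives 90000 nM. Compound 2 `O=[N+]([O-])c1ccc(-c2nc3cc(C(F)(F)F)ccc3[nH]2)cc1` gives 45000 nM in this assay, and the two numbers sit within the usual scatter of each other. Compound 1 `O=C(O)CCC(=O)Nc1ccc(-c2nc3cc(C(F)(F)F)ccc3[nH]2)cc1` gives > 100000 nM in this assay, which is a limit of the assay and not a number. Going by the values given here, the one measured step, an at least 2.2-fold lower number from compound 1 to compound 2 (0.34 log units; beyond the scatter), starts from that limit of > 100000 nM in this assay, at which 1 of the 3 values shown sits, and changes the group on the aromatic carbon, not the ring nitrogen.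

Compound 4 `CCN(CC)CC(=O)Nc1ccc(-c2nc3cc(C(F)(F)F)ccc3[nH]2)cc1` differs from compound 3 by hydrogen in place of methyl on an aromatic nitrogen. Among the compounds with values here, no measured step touches the aromatic nitrogen, so none bears directly on this change. Compound 1 and compound 2 both carry hydrogen at that position, and their values give no sign that this substitution moves the read-out in a fixed direction. He therefore expects no step beyond the scatter, no change at the digits printed from compound 3 to compound 4 (within the scatter). Compound 4 is expected to give about 90000 nM in this assay, with a likely range from 40000 nM to 200000 nM.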

Compound 4, half-maximal cytotoxic concentration: 24000 nM
Estimate against measurement, compound 4: 3.8-fold (0.57 log units) above, outside the stated range (below it).
By their numbers in this assay, from the lowest: compounds 4, 2 and 3 (each within the scatter of the next, the first and the last beyond it). At a limit, above all of these: compound 1.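

In this assay, going by these compounds alone, the aromatic nitrogen proves not to be a neutral position: hydrogen in place of methyl gives a 3.8-fold lower number from compound 3 to compound 4 (0.57 log units; beyond the scatter), the first measured step at this nitrogen and one that lies beyond the scatter. With hydrogen on that nitrogen, (((diethylamino)methyl)carbonyl)amino in place of nitro gives a 1.9-fold lower number from compound 2 to compound 4 (0.27 log units; within the scatter), so this pair shows no measurable difference between the two groups, although the change at the aromatic nitrogen in the diethylamino series does register. Diethylamino in place of carboxymethyl gives an at least 4.1-fold lower number from compound 1 to compound 4 (0.61 log units; beyond the scatter), a step that starts from a limit of the assay and not from a number: the limit of > 100000 nM in this assay, at which 1 of the 4 values shown sits.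

From the compounds shown here alone, the effect of the methyl rests on a single pair, so it stays open whether hydrogen in place of methyl would move the read-out the same way with the nitro group or the carboxylic acid chain on the aromatic carbon. Going by these compounds, it also stays open whether an ethyl group or a longer alkyl chain on the aromatic nitrogen would follow the methyl, follow the hydrogen, or fall elsewhere in this assay.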